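Methyl for nitro in a pair of compounds at the limit

A few compounds are considered here, and "the series" means these few. Any claim that something is new, unique, unknown or untested is made for them only; others in the source may bear on it.

Compound 1 `CC(C)n1ncc2c(C(=O)NCc3cn(-c4ccc(F)cc4)nn3)cccc21`: > 40000 nM
Compound 2 `CC(C)n1ncc2c(C(=O)NCc3cn(-c4ccc([N+](=O)[O-])cc4)nn3)cccc21`: > 40000 nM

In a functional assay on PC-3 cells (Homo sapiens) for inhibition, read by MTT assay, with a stated time of 72 h (on this read-out higher numbers stand for weaker inhibition and lower numbers for stronger inhibition), compound 1 gives > 40000 nM, which is a limit of the assay and not a number. Compound 2 likewise gives > 40000 nM in this assay, again only a limit. The step that the two limits leave unreadable from compound 1 to compound 2 therefore cannot be read, because of the limit of > 40000 nM in this assay, at which 2 of the 2 values shown sit. Compound 2 thus stands at the limit, with nothing to separate it from compound 1.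

Compound 3 `Cc1ccc(-n2cc(CNC(=O)c3cccc4c3cnn4C(C)C)nn2)cc1` differs from compound 2 by methyl in place of nitro on an aromatic carbon. No measured step bears on this change, and no size of step in this assay can be drawn from the numbers shown. The estimate is that the step of a number no higher from compound 2 to compound 3 (the limit leaves the size open) stays unreadable, with compound 3 expected to remain at the limit. Compound 3 is therefore estimated at 40000 nM, within 15000 nM to 100000 nM.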

Compound 3, half-maximal inhibitory concentration: 39000 nM
Compound 3: the middle estimate sits 1.0-fold (0.01 log units) above what was measured, and the stated range covers the measured number.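

Compound 3 is the only one of the three that returns a number in this assay, so this position now has one readable point, carrying 4-methylphenyl where compound 2 carries 4-nitrophenyl. Methyl in place of nitro gives an at least 1.0-fold lower number from compound 2 to compound 3 (0.01 log units; that floor lies within the scatter), and methyl in place of fluoro gives an at least 1.0-fold lower number from compound 1 to compound 3 (0.01 log units; that floor lies within the scatter). Both steps are floors that lie within the scatter, so neither shows a real gain on its own, and their true size stays open: the limit of > 40000 nM in this assay, at which 2 of the 3 values shown sit.

The compounds shown leave open whether any group at this position can move the number clearly away from that limit. An amine, a carboxylic acid or a chain longer than methyl at the same place could show whether the reading depends on this group at all.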